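A few compounds are considered here, and "the series" means these few. Any claim that something is new, unique, unknown or untested is made for them only; others in the source may bear on it.

Measured compounds:
- compound 1 `COc1cc2c(Oc3ccc(NC(=O)c4nn(-c5ccccc5OC(F)(F)F)c(=O)cc4C)cc3F)ccnc2cc1OCCCN1CCCCC1`: in a functional assay on A549 cells (Homo sapiens) for inhibition, read by MTT assay, with a stated time of 72 h (a higher number here means a weaker inhibitor, a lower number a stronger inhibitor), compound 1 gives 120 nM
- compound 2 `COc1cc2c(Oc3ccc(NC(=O)c4nn(-c5cccc(F)c5)c(=O)cc4C)cc3F)ccnc2cc1OCCCN1CCCC1`: in this assay compound 2 gives 170 nM

Compound 2 stands with the highest of the two numbers, but its nearest neighbour is compound 1, and the gap between the two values lies within the usual scatter of this assay, so the two compounds cannot be told apart on these data.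

Compound 3 `COc1cc2c(Oc3ccc(NC(=O)c4nn(-c5cccc(F)c5)c(=O)cc4C)cc3F)ccnc2cc1OCCCN1CCCCC1` has not been measured. It differs from compound 2 in one place: piperidin-1-yl in place of pyrrolidin-1-yl on a saturated chain carbon, three bonds along the chain from an oxygen on an aromatic ring. Going by the values given here, no pair of measured compounds shows this change on its own, so no step can be quoted for it. Compound 1 already carries the piperidin-1-yl group, together with a different aryl group on the shared core, and sits within the scatter of compound 2. The step from compound 2 to compound 3 is therefore expected to be small, with no direction beyond the scatter, which amounts to a 1.1-fold lower number from compound 2 to compound 3 (0.05 log units; within the scatter). Compound 3 is estimated at 150 nM, with a range from 60 nM to 400 nM.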

Compound 3, half-maximal inhibitory concentration: 250 nM
Compound 3: middle estimate off by 1.7-fold (0.22 log units), on the low side, and the stated range covers the measured number.
By their numbers in this assay, from the lowest: compounds 1, 2 and 3 (each within the scatter of the next, the first and the last beyond it).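

In this assay the change from pyrrolidin-1-yl to piperidin-1-yl at this chain end now has a step of its own (a 1.5-fold higher number from compound 2 to compound 3 (0.17 log units; within the scatter)), and it lies within the scatter, so on this pair the two rings cannot be told apart here. Going by these compounds alone, the aryl group on the aromatic nitrogen gives the only step beyond the scatter, and a modest one: with the piperidin-1-yl group held constant, 3-fluorophenyl in place of 2-(trifluoromethoxy)phenyl reads (a 2.1-fold higher number from compound 1 to compound 3 (0.32 log units; beyond the scatter)). No supporting evidence is available to explain either step.

The compounds shown leave open how a morpholin-4-yl or dimethylamino group at the end of this chain, or a longer chain, would read. They also leave open whether the aryl step holds when pyrrolidin-1-yl sits at the chain end.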